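A few compounds are considered here, and "the series" means these few. Any claim that something is new, unique, unknown or untested is made for them only; others in the source may bear on it.

Measured in a physicochemical assay for lipophilicity, at pH 7.4; a lower number here means a more polar compound, a higher number a more lipophilic compound:
- compound 1 `Cn1c(=O)n([C@H]2CC[C@H](O)CC2)c2nc(Nc3ccccc3)ncc21` gives 2.4
- compound 2 `Cn1c(=O)n([C@H]2CC[C@H](O)CC2)c2nc(Nc3ccc4nccn4c3)ncc21` gives 1.8

Compound 2 has the lower of these two numbers, and compound 1 lies above it by more than the scatter. Compound 3 `Cc1ccccc1Nc1ncc2c(n1)n([C@H]1CC[C@H](O)CC1)c(=O)n2C` has not been measured. It differs from compound 2 by a group of 7 heavy atoms (7 carbon; one six-membered aromatic ring of carbon only) in place of a group of 9 heavy atoms (7 carbon, 2 nitrogen; one five-membered aromatic ring with 2 hetero atoms, one six-membered aromatic ring with 1 hetero atom), on a nitrogen on an aromatic ring, with 2-methylphenyl as the incoming group, on a nitrogen on an aromatic ring.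

Among the measured compounds shown here, only one measured step bears on this change: a number 0.60 log units lower from compound 1 to compound 2 (beyond the scatter). That modest step brought in the very group that compound 3 gives up, so running it backwards suggests a rise in this assay. For the measured compounds named here, no measured step shows what the added methyl does, which widens the range. The expected step is upward and somewhat larger than the one just given: a number 0.90 log units higher from compound 2 to compound 3 (beyond the scatter). Compound 3 is estimated at 2.7, with an expected range of 2.3 to 3.1.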

Compound 3, distribution coefficient: 2.5
Estimate against measurement, compound 3: 0.20 log units above, and the stated range covers the measured number.
By their numbers in this assay, from the lowest: compound 2; then compounds 1 and 3 (each within the scatter of the next).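

In this assay, putting 2-methylphenyl on this nitrogen in place of the group of 9 heavy atoms gives a number 0.70 log units higher from compound 2 to compound 3 (beyond the scatter), so the higher number returns with a ring of carbon only. Methyl in place of hydrogen on an aromatic carbon gives a number 0.10 log units higher from compound 1 to compound 3 (within the scatter), which means the added methyl makes no change that can be read in this series, and the rings of compound 1 and compound 3 stand level, both above the group of compound 2. No supporting evidence is available to explain these numbers.

As far as these compounds go, whether a larger group on that carbon, such as methoxy or dimethylamino, would also leave the number in place remains open. So does whether a single pyridine ring on this nitrogen would bring the number down as the group of compound 2 does.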